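Benzyl in Place of 4-Chlorophenyl on an Aromatic Nitrogen

The source may report more compounds than this note shows. Statements on the series, on what has been measured and on what is new or still open speak of the compounds shown alone.

Compound 1, `CCCCCc1ccc(C#Cc2c(-c3ccc(CCCCC)cc3)oc3nc(=O)n(Cc4cn(-c5ccc(Cl)cc5)nn4)cc23)cc1`, in a functional assay on HeLa cells (Homo sapiens) for antiproliferative activity, read by MTT assay, with a stated time of 72 h; on this read-out higher numbers stand for weaker inhibition and lower numbers for stronger inhibition: compound 1 gives > 100000 nM, which is a limit of the assay and not a number.
Compound 2, `CCCCCCC#Cc1c(CCCCCC)oc2nc(=O)n(Cc3cn(-c4ccc(Cl)cc4)nn3)cc12`: compound 2 gives > 100000 nM, again a limit of the assay.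
Compound 3, `CCCCCCC#Cc1c(CCCCCC)oc2nc(=O)n(Cc3cn(Cc4ccccc4)nn3)cc12`: compound 3 gives 23400 nM.

Going by the values given here, the one measured step is the change from compound 2 to compound 3, (benzyl in place of 4-chlorophenyl on an aromatic nitrogen). This change brought an at least 4.2-fold lower number from compound 2 to compound 3 (0.63 log units; beyond the scatter). Its true size is not pinned down, since compound 2 sits at the limit of > 100000 nM in this assay, at which 2 of the 3 values shown sit, so the step is known only from one side.

Compound 4, `CCCCCc1ccc(C#Cc2c(-c3ccc(CCCCC)cc3)oc3nc(=O)n(Cc4cn(Cc5ccccc5)nn4)cc23)cc1`, has not been measured. Among the compounds with values here, it differs from compound 1 by benzyl in place of 4-chlorophenyl on an aromatic nitrogen, the same change, at the same place, as the one from compound 2 to compound 3. How the core of compound 1 differs from the core of compound 2 is not broken down here.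

For compound 4 the same direction is expected as in the measured step, but the starting point is only a limit, so the expected step is wide: the estimate is an at least 3.3-fold lower number from compound 1 to compound 4 (0.52 log units; beyond the scatter), resting on an at least 4.2-fold lower number from compound 2 to compound 3 (0.63 log units; beyond the scatter). Compound 4 is thus expected to give about 30000 nM in this assay, with a range from 8000 nM to 150000 nM, and with a real chance that it again returns only a limit.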

Compound 4, half-maximal inhibitory concentration: 73000 nM
Estimate against measurement, compound 4: 2.4-fold (0.39 log units) below, and the stated range covers the measured number.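

Compound 1 gives > 100000 nM in this assay, which is a limit of the assay and not a number. Replacing the 1-(4-chlorophenyl)-1H-1,2,3-triazol-4-yl group with the 1-benzyl-1H-1,2,3-triazol-4-yl group gives an at least 1.3-fold lower number from compound 1 to compound 4 (0.13 log units; that floor lies within the scatter), and since that floor lies within the usual scatter, this step alone does not establish a real drop. The change therefore points the same way on both cores, toward a lower number, but this is no proof that it carries over with the same size, or that its size depends on the core: the same change on two cores in this assay, an at least 4.2-fold lower number (0.63 log units; beyond the scatter) from compound 2 to compound 3 and an at least 1.3-fold lower number (0.13 log units; that floor lies within the scatter) from compound 1 to compound 4; the limit leaves it open whether they differ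

The compounds shown leave open whether the loss of the chlorine or the gain of the extra carbon in benzyl matters more, a question that a plain phenyl or a 4-chlorobenzyl group on the same nitrogen could help to settle. Also open, going by these compounds, is whether other changes, such as a shorter chain on the shared core or an amine at the end of a chain, would move the numbers further from the limit of the assay.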